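Series notes: chloro in place of methyl, compound 4

The compounds below may be only part of what the source reports. "The series", "measured", "known", "first", "only" and "open" are said of these compounds alone.

Three compounds have numbers in an assay on Sf21 cells for inhibition of cytochrome c oxidase subunit 2 (Homo sapiens), read by spectrophotometry, with a stated time of 5 min; a lower number here means a stronger inhibitor, a higher number a weaker inhibitor. Compound 1 `O=C1CCCCC1C1CC(=O)N(c2ccccc2)C1=O` gives 45100 nM. Compound 2 `NS(=O)(=O)c1ccc(N2C(=O)CC(C3CCCCCC3=O)C2=O)cc1` gives 20700 nM. Compound 3 `Cc1ccc(C(=O)CC2CC(=O)N(c3ccc(S(N)(=O)=O)cc3)C2=O)cc1` gives 980 nM, the lowest of the three numbers; the gaps to compound 2 and to compound 1 both lie beyond the scatter, so compound 3 stands as the strongest inhibitor of the measured set. Within the data shown here, no pair of these three compounds differs in only one place, so no single step between measured compounds can be read from them, and the numbers of compound 1 and compound 2 say only that both are weaker than compound 3.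

Compound 4 `NS(=O)(=O)c1ccc(N2C(=O)CC(CC(=O)c3ccc(Cl)cc3)C2=O)cc1` differs from compound 3 by chloro in place of methyl on an aromatic carbon, para to a large group. Nothing in the measured set shows what an exchange of this kind does in this assay, so the step is expected to stay within the scatter, with no clear direction, giving the estimated step of a 1.1-fold lower number from compound 3 to compound 4 (0.04 log units; within the scatter). Compound 4 is therefore estimated at 900 nM, with an expected range from 400 nM to 2500 nM.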

Compound 4, half-maximal inhibitory concentration: 6290 nM
Estimate against measurement, compound 4: 7.0-fold (0.84 log units) below; the whole stated range lies below it.
By their numbers in this assay, from the lowest: compound 3; then compound 4; then compound 2; then compound 1.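

In this assay, among these compounds, the exchange of 4-methylphenyl for 4-chlorophenyl gives a 6.4-fold higher number from compound 3 to compound 4 (0.81 log units; beyond the scatter) as the first step that can be read at a single place. The position on the aromatic carbon, para to a large group, therefore responds to the exchange: methyl and chloro each bring one heavy atom and no hydrogen-bond donors or acceptors, yet they are not interchangeable here, and compound 3 with methyl keeps the lower number. Nothing at hand bears on why the number rises with chloro.

As far as these compounds go, how far this position tolerates other groups remains open: fluoro, bromo, methoxy, an amine, a carboxylic acid or the unsubstituted phenyl could each show whether methyl is a favourable group here or chloro an unfavourable one. From the compounds shown here alone, this is also one pair on one scaffold, so it remains open whether the same exchange gives a step of similar size and direction elsewhere.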